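The source may report more compounds than this note shows. Statements on the series, on what has been measured and on what is new or still open speak of the compounds shown alone.

Compounds measured so far:
Compound 1, `Cc1ccccc1Nc1nc(Nc2cccnc2)ncc1Cl`: in a functional assay on MDA-MB-231 cells (Homo sapiens) for inhibition, read by CCK-8 assay, with a stated time of 48 h (a higher number here means a weaker inhibitor of growth, a lower number a stronger inhibitor of growth), compound 1 gives 41200 nM.
Compound 2, `Cc1ccccc1Nc1nc(NCc2ccco2)ncc1Cl`: in this assay compound 2 reaches only a limit of the assay, > 100000 nM, and not a number.
Compound 3, `Cc1ccccc1Nc1nc(Nc2ccc(N3CCN(C)CC3)cn2)ncc1Cl`: in this assay compound 3 gives 7470 nM.

Of the two compounds with a number in this assay, compound 3 stands lowest, and compound 1 sits a good way above it, beyond the scatter. Among the compounds with values here, the one measured step, an at least 2.4-fold higher number from compound 1 to compound 2 (0.38 log units; beyond the scatter), can be read only as a lower bound because of the limit of > 100000 nM in this assay, at which 1 of the 3 values shown sits.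

The unmeasured compound 4, `CC(C)c1ccccc1Nc1nc(Nc2ccc(N3CCN(C)CC3)cn2)ncc1Cl`, differs from compound 3 by isopropyl in place of methyl on an aromatic carbon. The change sits on an aromatic carbon of the six-membered aromatic ring of carbon only, ortho to a large group, so that the (2-methylphenyl)amino of compound 3 becomes (2-isopropylphenyl)amino. Within the data shown here, the single measured step exchanges the group on the nitrogen on the other side of the shared core; no step touches the ring changed here, so the series gives no guide to the size or direction of this change. With that, no step beyond the scatter is expected in this assay, and the step from compound 3 to compound 4 is estimated at a 1.2-fold higher number from compound 3 to compound 4 (0.08 log units; within the scatter). Compound 4 is therefore expected to give about 9000 nM in this assay, within 3000 nM to 30000 nM.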

Compound 4, concentration for 50% growth inhibition: 4090 nM
The estimate for compound 4 lay 2.2-fold (0.34 log units) above the measured number; the measured number falls inside the stated range.
By their numbers in this assay, from the lowest: compounds 4 and 3 (each within the scatter of the next); then compound 1. At a limit, above all of these: compound 2.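

Within the data shown here, the exchange of 2-methylphenyl for 2-isopropylphenyl gives the first reading on this side of the shared core, where the earlier compounds offered only a step on the opposite nitrogen: in this assay the step is a 1.8-fold lower number from compound 3 to compound 4 (0.26 log units; within the scatter). On this aromatic carbon, ortho to a large group, isopropyl with its 3 heavy atoms therefore stands in place of methyl with its 1 heavy atom without a step beyond the scatter, so compound 3 and compound 4 cannot be ranked against each other. Nothing in the evidence at hand bears on this result or offers a reason for it.

Still open, as far as these compounds go, is whether a larger or different group at this position, such as tert-butyl, methoxy or a primary amine, would give a step beyond the scatter in this assay. Also open, from the compounds shown here alone, is whether isopropyl in place of methyl reads the same when the pyridin-3-yl of compound 1, rather than the group carried by compound 3, sits on the other nitrogen.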